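This account rests on a few compounds, and the source may have more. Where it says the series, first, only, none or still open, it means among the compounds named here.

The measured compounds:
Compound 1 `COc1ccc(NS(=O)(=O)c2ccc(N3CCNC3=O)cc2)cc1`: in a functional assay on MCF7 cells (Homo sapiens) for antiproliferative activity, read by sulforhodamine B assay, with a stated time of 48 h (on this read-out higher numbers stand for weaker inhibition and lower numbers for stronger inhibition), compound 1 gives only a limit of the assay, > 1000 nM.
Compound 2 `O=C1NCCN1c1ccc(S(=O)(=O)Nc2cccc(Cl)c2)cc1`: in this assay compound 2 gives 79 nM.
Compound 3 `CCCCCCCc1ccc(NS(=O)(=O)c2ccc(N3CCNC3=O)cc2)cc1`: in this assay compound 3 gives only a limit of the assay, > 1000 nM.

Compound 3 therefore stands at a limit rather than at a number, a position it shares with one other value in the set, as the limit of > 1000 nM in this assay, at which 2 of the 3 values shown sit, records. The unmeasured compound 4 `O=C1NCCN1c1ccc(S(=O)(=O)Nc2ccc(F)cc2)cc1` differs from it in one place: fluoro in place of heptyl on an aromatic carbon. Among the compounds with values here, two measured steps bear on this change. The step that the two limits leave unreadable from compound 1 to compound 3 shows what exchanging groups on the aromatic carbon para to a large group did, but its size is hidden by the two limits. The step of an at least 12-fold lower number from compound 1 to compound 2 (1.10 log units; beyond the scatter) shows that a different substituent on the sulfonamide nitrogen can move the number far in the direction of stronger inhibition. Within the data shown here, since the only step at the same aromatic carbon is unreadable, the expectation for compound 4 rests on the exchange of heptyl for fluoro giving a number within reach of the assay rather than a limit. Compound 4 is expected to show a step of an at least 1.4-fold lower number from compound 3 to compound 4 (0.15 log units; that floor lies within the scatter), toward stronger inhibition, though of uncertain size. In this assay compound 4 is estimated at 700 nM, between 150 nM and 3000 nM.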

Compound 4, half-maximal inhibitory concentration: 690 nM
Estimate against measurement, compound 4: 1.0-fold (0.01 log units) above; measured number inside the range.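

With fluoro on an aromatic carbon para to a large group, compound 4 gives the first number for a substituent at this place, whereas heptyl in compound 3 and methoxy in compound 1 each leave only a limit of the assay: the limit of > 1000 nM in this assay, at which 2 of the 4 values shown sit.

The steps of an at least 1.4-fold lower number from compound 3 to compound 4 (0.16 log units; that floor lies within the scatter) and an at least 1.4-fold lower number from compound 1 to compound 4 (0.16 log units; that floor lies within the scatter) are therefore floors, so they show that the number came within reach in this assay but do not fix how far it moved. Within the data shown here, the one step read in full is an 8.7-fold higher number from compound 2 to compound 4 (0.94 log units; beyond the scatter), which shows that 4-fluorophenyl on the sulfonamide nitrogen does not match 3-chlorophenyl.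

The two aryl groups differ in both the halogen and its place on the ring, so the compounds shown cannot separate these two changes. They also leave open how a hydroxyl, an amine or a short chain such as ethyl on this aromatic carbon would stand against fluoro, and where along the way from fluoro to heptyl the number would pass into the limit.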